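This account rests on a few compounds, and the source may have more. Where it says the series, first, only, none or still open, it means among the compounds named here.

Measured compounds in a functional assay on MDA-MB-231 cells (Homo sapiens) for cytotoxicity, read by MTT assay, with a stated time of 48 h; on this read-out lower numbers stand for stronger inhibition and higher numbers for weaker inhibition:
- compound 1 `COc1cc(/C=C2\C(=O)Nc3ccc(Cl)cc32)ccc1OCCCN1CC(C)OC(C)C1`: 1990 nM
- compound 2 `COc1cc(/C=C2\C(=O)Nc3ccccc32)ccc1OCCCN1CCN(c2ccccn2)CC1`: > 20000 nM; this is a limit of this assay, not a number.

Compound 2 stands at the limit: the limit of > 20000 nM in this assay, at which 1 of the 2 values shown sits. Among the measured compounds shown here, only compound 1 carries a number, and compound 1 differs from compound 2 in two places, so the two values show only that compound 1 is inside the measurable range and compound 2 is not.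

Compound 3 `COc1cc(/C=C2\C(=O)Nc3ccc(Cl)cc32)ccc1OCCCN1CCN(c2ccccn2)CC1` is compound 2 with one change: chloro in place of hydrogen on an aromatic carbon. For the measured compounds named here, no single-change step is available to set its size. Going by the values given here, compound 1, the only compound with a chloro at that position, gives 1990 nM, which suggests the change might bring compound 3 back inside the range, but the other difference to compound 1 is unaccounted for. The expected step is an at least 1.6-fold lower number from compound 2 to compound 3 (0.22 log units; that floor lies within the scatter), a modest gain that may not clear the scatter. Compound 3 is estimated at 12000 nM, within 3500 nM to 40000 nM, with a real chance that only a limit is reported.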

Compound 3, half-maximal inhibitory concentration: 14800 nM
Compound 3: middle estimate off by 1.2-fold (0.09 log units), on the low side; low and high end bracket the measured number.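

With the chloro in place of hydrogen on an aromatic carbon, the 4-(pyridin-2-yl)piperazin-1-yl compounds now have a number in this assay, and the change gives an at least 1.3-fold lower number from compound 2 to compound 3 (0.13 log units; that floor lies within the scatter). On these data alone, compound 2 gives only a limit, so the true size of this step stays open: the limit of > 20000 nM in this assay, at which 1 of the 3 values shown sits. Among the compounds shown here, with the chloro shared, the group on the chain can now be compared, and 4-(pyridin-2-yl)piperazin-1-yl in place of 2,6-dimethylmorpholin-4-yl gives a 7.4-fold higher number from compound 1 to compound 3 (0.87 log units; beyond the scatter), the only step here with a measured size.

The compounds shown have no partner for compound 1 without the chloro, so the effect of the chloro with 2,6-dimethylmorpholin-4-yl on the chain remains unknown. Also open, as far as these compounds go, is how a fluoro or a methoxy at the same aromatic carbon, or a piperidine at the chain end, would read.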